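This account rests on a few compounds, and the source may have more. Where it says the series, first, only, none or still open, it means among the compounds named here.

Measured so far in a functional assay on A549 cells (Homo sapiens) for cytotoxicity, read by MTT assay, with a stated time of 72 h; a higher number here means that more compound is needed for the effect, a lower number that less compound is needed:

- Compound 1 `CCc1cccc2c(OC)c(-c3occ(C)c3C(=O)OC)ccc12` gives 1.5 ug/mL
- Compound 2 `CCOc1c(-c2occ(C)c2C(=O)O)ccc2c(CC)cccc12` reports only a limit of the assay, > 10 ug/mL
- Compound 3 `CCOc1c(-c2occ(C)c2C(=O)OC)ccc2c(CC)cccc12` gives 2.4 ug/mL

Compound 3 and compound 1 cannot be told apart, with a 1.6-fold higher number from compound 1 to compound 3 (0.20 log units; within the scatter), and that change lies elsewhere on the molecule. Compound 4 `CCOc1c(-c2occ(C)c2CO)ccc2c(CC)cccc12` has hydroxymethyl in place of methoxycarbonyl on an aromatic carbon. The closest evidence concerns this same group, where methyl replaces hydrogen on an oxygen next to a carbonyl group, giving an at least 4.1-fold lower number from compound 2 to compound 3 (0.61 log units; beyond the scatter). That step shows the group can matter, but compound 4 has no carbonyl there, so it is only a loose guide. A modest change is expected, estimated as a 1.5-fold higher number from compound 3 to compound 4 (0.16 log units; within the scatter). For compound 4 the estimated value is 3.5 ug/mL, with an expected range from 1.2 ug/mL to 10 ug/mL.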

Compound 4, concentration for half-maximal effect: > 10 ug/mL
Compound 4 ended at the assay's limit; the forecaster's own chance of this, stated with the estimate: 15%; middle value at least 2.8-fold (0.45 log units) from the limit.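

Replacing methoxycarbonyl with hydroxymethyl at this position gives an at least 4.1-fold higher number from compound 3 to compound 4 (0.61 log units; beyond the scatter) in this assay. Of the three groups shown on this aromatic carbon, only methoxycarbonyl gives a readable value, so losing the carbonyl does not rescue what the carboxy group of compound 2 lacked. Compound 2 and compound 4 both stop at a limit of the assay, not a number, so the step between them cannot be read: the limit of > 10 ug/mL in this assay, at which 2 of the 4 values shown sit.

As far as these compounds go, what stays open is whether the ester itself is needed, or whether an ethyl ester or an amide on this carbon would also keep the effect.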